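The compounds below may be only part of what the source reports. "The series", "measured", "known", "first", "only" and "open" are said of these compounds alone.

Measured compounds:
compound 1, `FC(F)(F)c1ccc(C2CC(c3ccccc3)=NN2c2ccc(-c3ccccc3)nn2)cc1`, 100000 nM in a functional assay on MCF7 cells (Homo sapiens) for antiproliferative activity, read by MTT assay, with a stated time of 24 h; a lower number here means a stronger inhibitor, a higher number a weaker inhibitor;
compound 2, `Clc1ccc(C2=NN(c3ccc(-c4ccccc4)nn3)C(c3ccccc3)C2)cc1`, 10000 nM;
compound 3, `Clc1ccc(C2=NN(c3ccc(-c4ccccc4)nn3)C(c3ccc(Cl)cc3)C2)cc1`, 8800 nM.

Compound 3 gives the lowest number of the three in this assay, but its nearest neighbour, compound 2, sits within the scatter of it: a 1.1-fold lower number from compound 2 to compound 3 (0.06 log units; within the scatter). Only compound 1 stands clearly apart, with a number higher than that of compound 3 by more than the scatter.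

Compound 4, `FC(F)(F)c1ccc(C2CC(c3ccc(Cl)cc3)=NN2c2ccc(-c3ccccc3)nn2)cc1`, is not yet measured. It differs from compound 3 in one place: trifluoromethyl in place of chloro on an aromatic carbon. Among the compounds with values here, no measured step carries exactly this change. What the values show is that compound 1, which bears the same trifluoromethyl on the same ring as compound 4, gives the weakest number of the set, while the chloro on the other ring, the difference between compound 2 and compound 3, moves the number only within the scatter. On that basis compound 4 is expected to land close to compound 1, with an expected step of a 6.8-fold higher number from compound 3 to compound 4 (0.83 log units; beyond the scatter). The estimate for compound 4 is 60000 nM, with a range from 15000 nM to 150000 nM.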

Compound 4, half-maximal inhibitory concentration: 1670 nM
Estimate against measurement, compound 4: 36-fold (1.56 log units) above; the measured number lies below the stated range.
By their numbers in this assay, from the lowest: compound 4; then compounds 3 and 2 (each within the scatter of the next); then compound 1.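

In this assay, trifluoromethyl on this aromatic carbon, para to a large group, does not by itself go with a high number once the other ring carries chloro: a 5.3-fold lower number from compound 3 to compound 4 (0.72 log units; beyond the scatter), and with hydrogen as the starting point the change gives a 6.0-fold lower number from compound 2 to compound 4 (0.78 log units; beyond the scatter). Compound 1 alone had pointed the other way, yet adding chloro to its other ring gives a 60-fold lower number from compound 1 to compound 4 (1.78 log units; beyond the scatter). The two groups therefore do not add up independently, and the effect of chloro in place of hydrogen depends on the core that carries it: the same change on two cores in this assay, a 1.1-fold lower number (0.06 log units; within the scatter) from compound 2 to compound 3 and a 60-fold lower number (1.78 log units; beyond the scatter) from compound 1 to compound 4, 53-fold (1.72 log units) apart, beyond the scatter of two such steps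

Going by these compounds, whether a methoxy group or an amine at this place would follow trifluoromethyl or chloro remains open. Also open, on these data alone, is whether the dependence on the other ring would hold with a carboxylic acid there in place of chloro.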